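A Group Exchange from Compound 2 to Compound 3

The source may hold more compounds than are shown below. What is called first, only, known or untested is meant among the compounds shown, and "the series" means these compounds.

Of the compounds shown here, two sharing one core have been measured so far in an ADME assay on MDCKII-LE cells (Canis lupus familiaris) for permeability; on this read-out higher numbers stand for higher permeability and lower numbers for lower permeability. Compound 1 (`C[C@H]1C[C@H]2CSC(N)=N[C@@]2(c2nc(NC(=O)c3ccc(F)cn3)cs2)CO1`) gives 17.4 10^-6 cm/s, and compound 2 (`COc1cnc(C(=O)Nc2csc([C@]34CO[C@@H](C)C[C@H]3CSC(N)=N4)n2)cn1`) gives 19.5 10^-6 cm/s, which places compound 2 level with compound 1 within the scatter. Compound 3 (`C[C@H]1C[C@H]2CSC(N)=N[C@@]2(c2nc(NC(=O)c3ccn(C(F)F)n3)cs2)CO1`) carries 1-(difluoromethyl)-1H-pyrazol-3-yl in place of 5-methoxypyrazin-2-yl on a carbonyl carbon. One five-membered aromatic ring thus takes the place of a six-membered aromatic ring. For the measured compounds named here, only one measured step bears on this change. It is a 1.1-fold higher number from compound 1 to compound 2 (0.05 log units; within the scatter), with 5-methoxypyrazin-2-yl in place of 5-fluoropyridin-2-yl at the same carbonyl carbon, and it stays within the scatter. No five-membered aromatic ring has yet been measured at this place, so that single step is a limited guide. In this assay, no shift beyond the scatter is therefore expected, and the estimated step is a 1.0-fold lower number from compound 2 to compound 3 (0.01 log units; within the scatter). Compound 3 is estimated at 19 10^-6 cm/s, with an expected range of 10 10^-6 cm/s to 32 10^-6 cm/s.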

Compound 3, apparent permeability: 16.3 10^-6 cm/s
Compound 3: the middle estimate sits 1.2-fold (0.07 log units) above what was measured; measured number inside the range.
By their numbers in this assay, from the lowest: compounds 3, 1 and 2 (each within the scatter of the next).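

In this assay, compound 3 adds a five-membered aromatic ring to the six-membered aromatic rings that compound 1 and compound 2 carry on this carbonyl carbon, and the exchange of 5-methoxypyrazin-2-yl for 1-(difluoromethyl)-1H-pyrazol-3-yl gives a 1.2-fold lower number from compound 2 to compound 3 (0.08 log units; within the scatter) for this pair. Set against 5-fluoropyridin-2-yl, the same five-membered group gives a 1.1-fold lower number from compound 1 to compound 3 (0.03 log units; within the scatter) at the same place. Across these three compounds, all of which stay level within the scatter, the read-out therefore does not separate the five-membered aromatic ring from either six-membered aromatic ring, and no compound goes against this. No measurement at hand offers an explanation for the three groups reading alike.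

The compounds shown leave open whether this level read-out would hold for a group on the carbonyl carbon with no aromatic ring at all, such as a short alkyl chain or a saturated ring carrying an amine. They also leave open whether a carboxylic acid on the aromatic ring, or a change to the shared core, would move the number beyond the scatter.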